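The source may report more compounds than this note shows. Statements on the series, on what has been measured and on what is new or still open speak of the compounds shown alone.

In a functional assay on A549 cells (Homo sapiens) for antiproliferative activity, read by MTT assay, with a stated time of 72 h (a higher number here means a weaker inhibitor, a lower number a stronger inhibitor), compound 1 `COc1cc(C(=O)c2sc3ccccc3c2-c2ccc(SC)cc2)cc(OC)c1OC` gives 5400 nM. As far as these compounds go, compound 2 `COc1ccc(OC)c(-c2c(C(=O)c3cc(OC)c(OC)c(OC)c3)sc3ccccc23)c1` reaches only a limit of the assay, > 10000 nM, so its true position is unknown. Compound 3 `COc1ccc(-c2c(C(=O)c3cc(OC)c(OC)c(OC)c3)sc3ccccc23)cc1C` has 4-methoxy-3-methylphenyl in place of 2,5-dimethoxyphenyl on an aromatic carbon. Going by the values given here, the one measured step that bears on this is an at least 1.8-fold higher number from compound 1 to compound 2 (0.26 log units; that floor lies within the scatter), where 2,5-dimethoxyphenyl replaced 4-(methylsulfanyl)phenyl. Removing 2,5-dimethoxyphenyl may therefore bring the number back towards that of compound 1, but only modestly. The expected step is an at least 1.4-fold lower number from compound 2 to compound 3 (0.15 log units; that floor lies within the scatter), small and towards a lower number. For compound 3 the estimated value is 7000 nM, with an expected range of 2000 nM to 25000 nM.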

Compound 3, half-maximal inhibitory concentration: > 10000 nM
Compound 3: only a limit was reported; the forecaster's own chance of this, stated with the estimate: 35%; middle value at least 1.4-fold (0.15 log units) from the limit.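

Putting 4-methoxy-3-methylphenyl in place of 4-(methylsulfanyl)phenyl on this aromatic carbon gives an at least 1.8-fold higher number from compound 1 to compound 3 (0.26 log units; that floor lies within the scatter) in this assay. A second group at this position therefore leaves the reading at a limit of the assay, not at a measured number. The step from compound 2 to compound 3 cannot be read because both compounds stop at the same limit: the limit of > 10000 nM in this assay, at which 2 of the 3 values shown sit.

As far as these compounds go, it remains open how far past that limit compound 2 and compound 3 truly lie. From the compounds shown here alone, it is also open whether a phenyl ring carrying an amine or a carboxylic acid here would give a lower number than compound 1.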